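A few compounds are considered here, and "the series" means these few. Any claim that something is new, unique, unknown or untested is made for them only; others in the source may bear on it.

Working notes on the series, which so far holds two measured compounds. In a functional assay on HepG2 cells (Homo sapiens) for inhibition, read by MTT assay, with a stated time of 72 h (on this read-out lower numbers stand for stronger inhibition and higher numbers for weaker inhibition), compound 1 (`CCCCc1ccc(NC(=O)C2CCN(C/C=C/c3ccccc3)CC2)cc1`) gives 4320 nM and compound 2 (`O=C(Nc1cccc(Cl)c1)C1CCN(C/C=C/c2ccccc2)CC1`) gives 20000 nM as the higher of the two numbers. The gap between them lies beyond the scatter, so compound 2 is the weaker of the pair.

The next entry is compound 3 (`N#Cc1ccc(NC(=O)C2CCN(C/C=C/c3ccccc3)CC2)cc1`), which carries 4-cyanophenyl in place of 3-chlorophenyl on an amide-type nitrogen. Among the compounds with values here, no measured pair shows this exchange, so the expectation rests on very little. Compound 2 at 20000 nM sits at the top of the measured range, and compound 1 at 4320 nM shows that a change of the group on that nitrogen can go with a lower number. A slight downward move is therefore expected, probably not clearly beyond the scatter. The estimated step is a 1.8-fold lower number from compound 2 to compound 3 (0.26 log units; within the scatter) in this assay on this reasoning. For compound 3 the expected value is 11000 nM with an estimated range of 3500 nM to 30000 nM in this read-out.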

Compound 3, half-maximal inhibitory concentration: 38300 nM
Beside the measured number, compound 3's estimate is 3.5-fold (0.54 log units) below it, and the stated range ends below it.
By their numbers in this assay, from the lowest: compound 1; then compounds 2 and 3 (each within the scatter of the next).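

In this assay, 4-cyanophenyl in place of 3-chlorophenyl on an amide-type nitrogen gives a 1.9-fold higher number from compound 2 to compound 3 (0.28 log units; within the scatter), so this exchange does not separate the two compounds, even though it alters both the substituent and its printed place on the ring. Cyano in place of butyl on an aromatic carbon gives an 8.9-fold higher number from compound 1 to compound 3 (0.95 log units; beyond the scatter), the first exchange at a single place in the series to lie beyond the scatter, and it shows that the substituent on this aromatic ring can matter, with butyl going with the lower number in this one pair. The data at hand offer no measured basis for explaining either step.

The compounds shown leave open whether the lower number of compound 1 depends on chain length, which a shorter ethyl or a longer hexyl chain at the same place would test. They also leave open how an amine or a carboxylic acid on that aromatic carbon would compare with butyl and cyano in this read-out.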